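The source may report more compounds than this note shows. Statements on the series, on what has been measured and on what is new or still open speak of the compounds shown alone.

Measured in a functional assay on HT-29 cells (Homo sapiens) for cytotoxicity, read by MTT assay, with a stated time of 72 h; a lower number here means a stronger inhibitor, a higher number a weaker inhibitor:

compound 1 `COc1cc2c(Oc3ccc(NC(=O)c4cn(-c5c(C)cccc5C)nn4)cc3F)ccnc2cc1OCCCN1CCCC1` gives 2240 nM
compound 2 `COc1cc2c(Oc3ccc(NC(=O)c4cn(-c5c(C)cccc5C)nn4)cc3F)ccnc2cc1OCCCN1CCCCC1` gives 3690 nM
compound 3 `COc1cc2c(Oc3ccc(NC(=O)c4cn(-c5ccccc5F)nn4)cc3F)ccnc2cc1OCCCN1CCC(C)CC1` gives 210 nM

Compound 3 stands lowest of the three numbers in this assay; its nearest neighbour is compound 1 and the furthest is compound 2, both gaps beyond the scatter. Compound 4 `COc1cc2c(Oc3ccc(NC(=O)c4cn(-c5c(C)cccc5C)nn4)cc3F)ccnc2cc1OCCCN1CCC(C)CC1` is not yet measured. It differs from compound 3 as follows: 2,6-dimethylphenyl in place of 2-fluorophenyl on an aromatic nitrogen. Among the compounds with values here, no measured pair isolates this change. Within the data shown here, the only single-point step on record, a 1.6-fold higher number from compound 1 to compound 2 (0.22 log units; within the scatter), concerns the amine ring at the end of the chain and lies within the scatter. Compounds 1 and 2 already carry the 2,6-dimethylphenyl group and sit well above compound 3, which carries the 2-fluorophenyl group together with the 4-methylpiperidinyl amine. Since the amine variation between compound 1 and compound 2 moved the number little, the gap between compound 3 and compound 1 is most simply read as belonging to the aryl group. Compound 4 is therefore expected to lose most of the advantage of compound 3, a step of a 12-fold higher number from compound 3 to compound 4 (1.08 log units; beyond the scatter). The estimate for compound 4 in this assay is 2500 nM, with a range of 900 nM to 7000 nM.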

Compound 4, half-maximal inhibitory concentration: 2450 nM
Estimate against measurement, compound 4: 1.0-fold (0.01 log units) above; low and high end bracket the measured number.
By their numbers in this assay, from the lowest: compound 3; then compounds 1, 4 and 2 (each within the scatter of the next).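

In this assay, the aryl group on the aromatic nitrogen now stands as a single change: 2,6-dimethylphenyl in place of 2-fluorophenyl gives a 12-fold higher number from compound 3 to compound 4 (1.07 log units; beyond the scatter) and is large enough to separate compound 3 from the rest of the set. With 2,6-dimethylphenyl held fixed, the amine end does not separate the compounds: the methyl on the saturated ring carbon gives a 1.5-fold lower number from compound 2 to compound 4 (0.18 log units; within the scatter) and 4-methylpiperidin-1-yl in place of pyrrolidin-1-yl gives a 1.1-fold higher number from compound 1 to compound 4 (0.04 log units; within the scatter) and both lie within the scatter. Nothing at hand explains the size of the aryl step.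

From the compounds shown here alone, whether that step tracks the fluorine or the two methyl groups stays open, and phenyl, 2-methylphenyl or 2,6-difluorophenyl on the same nitrogen would separate the two. Going by these compounds, only compound 3 carries 2-fluorophenyl, so it also stays open whether other amines, such as a morpholine at the chain end, would stay as close together with that group.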